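The source may hold more compounds than are shown below. What is called first, only, known or untested is meant among the compounds shown, and "the series" means these compounds.

Compound 1 `C[C@@H]1CN(c2ncccc2C(F)(F)F)CCN1C(=O)Nc1ccc(C(F)(F)F)cc1` gives 11 nM in a functional assay for antagonist activity at transient receptor potential cation channel subfamily V member 1 (Rattus norvegicus); on this read-out lower numbers stand for stronger inhibition and higher numbers for weaker inhibition.
Compound 2 `CC(C)(C)c1ccc(NC(=O)c2ccc(-c3ncccc3F)cc2)cc1` gives 1 nM in this assay.

Of the two compounds measured in this assay, compound 2 stands at the lowest number; compound 1 sits at a higher number, and that gap is beyond the usual scatter of the measurement. The two structures differ in more than one place, so nothing is said here about which part of the difference carries that gap.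

Compound 3 `CC(C)(C)c1ccc(NC(=O)c2ccc(-c3ncccc3NC3CCCC3)cc2)cc1` is not yet measured in this assay. It differs from compound 2 in one place: cyclopentylamino in place of fluoro on an aromatic carbon. Going by the values given here, no measured pair shows what such an exchange does on this core. Starting from the very low number of compound 2, the step from compound 2 to compound 3 is expected to be a 5.0-fold higher number from compound 2 to compound 3 (0.70 log units; beyond the scatter), toward a somewhat higher number. Compound 3 is therefore estimated at 5 nM, in the range from 1 nM to 30 nM.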

Compound 3, half-maximal inhibitory concentration: 44 nM
The estimate for compound 3 lay 8.8-fold (0.94 log units) below the measured number; measured number outside the range, above it.
By their numbers in this assay, from the lowest: compound 2; then compound 1; then compound 3.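

Replacing fluoro with cyclopentylamino on this aromatic carbon, two atoms from the ring nitrogen, gives a 44-fold higher number from compound 2 to compound 3 (1.64 log units; beyond the scatter) in this assay, a large step beyond the scatter. This pair shows that the position is sensitive to the exchange: the change from a single fluorine to a group of six heavy atoms, with a five-membered non-aromatic ring and a hydrogen-bond donor, weakens inhibition markedly, although compound 3 still gives a number of 44 nM in this assay. No measurement shown here accounts for the size of this step.

The exchange alters the linking nitrogen, the ring and the size of the group all at once, so the compounds shown cannot assign the loss to any one of these. A plain amino group, a methylamino group or a directly attached cyclopentyl group at this position would begin to separate these contributions.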